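From 3-Methylphenyl to 4-Chlorophenyl on the Alkyne

A few compounds are considered here, and "the series" means these few. Any claim that something is new, unique, unknown or untested is made for them only; others in the source may bear on it.

compound 1 `Cc1cccc(C#Cc2ccc3c(n2)CCN(C)C3=O)c1`: 820 nM
compound 2 `Cc1ccc(C#Cc2ccc3c(n2)CCN(C)C3=O)cc1`: 7450 nM
compound 3 `Cc1cccc(C#Cc2ccc3c(n2)CCN(C(C)C)C3=O)c1`: 510 nM

In an assay on HEK293 cells for displacement of a labelled ligand from metabotropic glutamate receptor 5 (Homo sapiens), with a stated time of 2 h (on this read-out higher numbers stand for weaker inhibition and lower numbers for stronger inhibition), compound 3 gives the lowest number of the three, but its gap to compound 1, a 1.6-fold lower number from compound 1 to compound 3 (0.21 log units; within the scatter), lies within the scatter, so those two cannot be ordered; only compound 2 stands clearly apart. Compound 4 `CC(C)N1CCc2nc(C#Cc3ccc(Cl)cc3)ccc2C1=O` differs from compound 3 by 4-chlorophenyl in place of 3-methylphenyl on a triple-bonded carbon. Among the compounds with values here, the one measured step that bears on this is a 9.1-fold higher number from compound 1 to compound 2 (0.96 log units; beyond the scatter), where 4-methylphenyl replaced 3-methylphenyl on the same triple-bonded carbon. Within the data shown here, compound 4 likewise carries a 4-substituted phenyl, although no measured pair tests chlorine against methyl, so that part of the change is untested. Compound 4 is therefore expected to give a higher number than compound 3, by roughly a 5.9-fold higher number from compound 3 to compound 4 (0.77 log units; beyond the scatter). The estimate for compound 4 is 3000 nM, in the range 700 nM to 12000 nM.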

Compound 4, inhibition constant: 27100 nM
For compound 4 the middle estimate is 9.0-fold (0.96 log units) below the measured one, and the stated range ends below it.
By their numbers in this assay, from the lowest: compounds 3 and 1 (each within the scatter of the next); then compound 2; then compound 4.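

On the triple-bonded carbon, the change to 4-chlorophenyl carries a much larger penalty than the earlier step suggested: in this assay there is a 53-fold higher number from compound 3 to compound 4 (1.73 log units; beyond the scatter) and the step with 4-methylphenyl was a 9.1-fold higher number from compound 1 to compound 2 (0.96 log units; beyond the scatter). In both pairs shown, 3-methylphenyl goes with the lower number. No measurement shown accounts for the size of the new step. The compounds shown leave open how much of that step belongs to the chlorine itself, and whether a 3-chlorophenyl group on the same carbon would give a number close to that of compound 3.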